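The source may hold more compounds than are shown below. What is called first, only, known or untested is meant among the compounds shown, and "the series" means these compounds.

In a functional assay on PC-3 cells (Homo sapiens) for antiproliferative activity, read by MTT assay, with a stated time of 72 h (a higher number here means a weaker inhibitor, a lower number a stronger inhibitor), compound 1 (`O=C(N/N=C/c1ccc(F)cc1)Nc1ccc(Oc2ccnc3[nH]ccc23)c(F)c1`) gives 2330 nM as its reading. Compound 2 (`O=C(N/N=C/c1cccc(Cl)c1Cl)Nc1ccc(Oc2ccnc3[nH]ccc23)c(F)c1`) shares the core of compound 1, but compound 2 is recorded as "not active" (no number reported) in the same test series. Among the compounds with values here, it therefore has no single number, and no step can be measured from it.

Compound 3 (`O=C(N/N=C/c1cc(Br)c(O)c(Br)c1)Nc1ccc(Oc2ccnc3[nH]ccc23)c(F)c1`) keeps that shared core and differs from compound 2 in one group. The change is 3,5-dibromo-4-hydroxyphenyl in place of 2,3-dichlorophenyl on a carbon with a double bond to nitrogen and, in words, 3,5-dibromo-4-hydroxyphenyl takes the place of 2,3-dichlorophenyl on a carbon with a double bond to nitrogen.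

With so few compounds, any forecast is loose. In this assay a move toward a stronger inhibitor is expected, of a size that cannot be stated from a starting point without a number. The expected landing place is close to compound 1 at 2330 nM as the only measured reference. Another result without a number also remains possible.

The estimated value for compound 3 is 3000 nM with an expected range of 800 nM to 12000 nM as a working guess.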

Compound 3, half-maximal inhibitory concentration: "not active" (no number reported)
The entry for compound 3 holds no number; the estimate stays without a comparison.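

In this assay compound 2 and compound 3 are both recorded as "not active" with no number, so no step can be read between them. No measured evidence shown here bears on this result. Still open, as far as these compounds go, is how either compound would compare numerically with compound 1, which gives 2330 nM.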